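Swapping the branch beside the acid on the chain

The compounds below may be only part of what the source reports. "The series", "measured", "known", "first", "only" and "open" are said of these compounds alone.

Compound 2 `C=C(C)C(CCC/C=C(\c1ccccc1)c1cccnc1)C(=O)O` carries a carboxylic acid and a 1-methylethenyl branch on its chain. Among the compounds with values here, in an assay (Equus caballus) for inhibition of Thromboxane-A synthase (Homo sapiens), using microsomes (on this read-out higher numbers stand for weaker inhibition and lower numbers for stronger inhibition), compound 2 gives 28 nM, the lowest of the three numbers measured so far. Compound 3 `COC(=O)CCCC/C=C(\c1ccccc1)c1cccnc1`, a methyl ester with an unbranched chain, gives 100 nM in this assay, and compound 1 `NC(=O)CCCC/C=C(\c1ccccc1)c1cccnc1`, the corresponding amide, gives 400 nM. The measured steps are a 4.0-fold lower number from compound 1 to compound 3 (0.60 log units; beyond the scatter), a 14-fold lower number from compound 1 to compound 2 (1.15 log units; beyond the scatter) and a 3.6-fold higher number from compound 2 to compound 3 (0.55 log units; beyond the scatter).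

Compound 4 `O=C(O)C(CCC/C=C(\c1ccccc1)c1cccnc1)C1(O)CCCC1` keeps the acid but alters the branch: 1-hydroxycyclopentyl in place of 1-methylethenyl on a saturated chain carbon bound to a carbonyl carbon and a saturated chain carbon. Within the data shown here, no measured step changes the branch alone. The step from compound 2 to compound 3 bundles loss of the branch with conversion of the acid into an ester, and it was only modest. Among the measured compounds shown here, the acid is retained in compound 4, so the large step of a 14-fold lower number from compound 1 to compound 2 (1.15 log units; beyond the scatter), which introduced the acid, has no counterpart here. The expectation is therefore a small step, at or near the scatter, a 1.4-fold higher number from compound 2 to compound 4 (0.15 log units; within the scatter). Compound 4 is estimated at 40 nM, with a likely range from 12 nM to 130 nM.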

Compound 4, half-maximal inhibitory concentration: 65 nM
Beside the measured number, compound 4's estimate is 1.6-fold (0.21 log units) below it; the range from low to high includes it.
By their numbers in this assay, from the lowest: compound 2; then compounds 4 and 3 (each within the scatter of the next); then compound 1.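

Within the data shown here, this is the first measured change confined to the branch, with the carboxylic acid held constant, and in this assay it gives a modest shift: a 2.3-fold higher number from compound 2 to compound 4 (0.37 log units; beyond the scatter). The saturated chain carbon bound to a carbonyl carbon and a saturated chain carbon can therefore carry 1-hydroxycyclopentyl, with 6 heavy atoms to the 3 of 1-methylethenyl, a ring and a hydrogen-bond donor and acceptor, and the number moves only this far. The swap changes several things at once, though, so the step belongs to the whole replacement and not to any single feature of it. No measurement available here explains why the number rises.

Going by these compounds, a plain cyclopentyl branch, without the hydroxyl, would help separate the part played by the ring from that of the hydroxyl, so that question stays open. Also open, on these data alone, is what an unbranched carboxylic acid on the same chain would give, a comparison that would show what each branch contributes by itself.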